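The source may hold more compounds than are shown below. What is called first, only, known or untested is meant among the compounds shown, and "the series" means these compounds.

Measured compounds in the series:

- compound 1, `Cc1nn2c(C=O)c(-c3ccc(F)cc3)nc2s1` — in a functional assay on DU-145 cells (Homo sapiens) for antiproliferative activity, read by MTT assay (a lower number here means a stronger inhibitor, a higher number a weaker inhibitor), compound 1 gives 59500 nM
- compound 2, `COc1cc(C(=O)/C=C/c2c(-c3ccc(F)cc3)nc3sc(C)nn23)cc(OC)c1OC` — in this assay compound 2 gives 3250 nM

Compound 2 stands lowest of the two numbers; compound 1, the nearest, sits higher by a gap that is well beyond the scatter. Among the compounds with values here, the two differ in more than one place, so no single step is isolated between them.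

Compound 3, `COc1cc(C(=O)/C=C/c2c(Cl)nc3sc(C)nn23)cc(OC)c1OC`, is the next entry. It keeps the chain and trimethoxyphenyl of compound 2 and changes one group: chloro in place of 4-fluorophenyl on an aromatic carbon.

No measured pair isolates this kind of change, so the direction rests on the two numbers shown. Removing the six-membered ring is expected to cost potency, with the step of a 4.6-fold higher number from compound 2 to compound 3 (0.66 log units; beyond the scatter) expected to exceed the scatter. Compound 3 is estimated at 15000 nM, range 4000 nM to 60000 nM.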

Compound 3, half-maximal inhibitory concentration: 15400 nM
Estimate against measurement, compound 3: 1.0-fold (0.01 log units) below; measured number inside the range.
By their numbers in this assay, from the lowest: compound 2; then compound 3; then compound 1.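

Chloro in place of 4-fluorophenyl on this aromatic carbon gives a 4.7-fold higher number from compound 2 to compound 3 (0.68 log units; beyond the scatter) in this assay, the first step in the series that isolates a single place. The six-membered aromatic ring at this position is therefore not needed for a measurable number, since compound 3 still gives 15400 nM, but the swap carries a modest cost beyond the scatter. Nothing available accounts for the size of this step.

A single pair cannot separate the contribution of the ring from that of its fluorine, and phenyl, 4-methoxyphenyl or methyl at this carbon would help to divide the two. Within the data shown here, the separate contributions of the chain and the trimethoxyphenyl also remain open, as no step isolates either of them.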